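Cyclohexyl in place of hexyl on an aromatic nitrogen

This account rests on a few compounds, and the source may have more. Where it says the series, first, only, none or still open, it means among the compounds named here.

compound 1 `N[C@H]1CC[C@H](Nc2nc(Nc3ccc(Cl)cc3)c3ncn(C4CCCCC4)c3n2)CC1`: 140 nM
compound 2 `CCCCCCn1cnc2c(Nc3cc(OC)cc(OC)c3)nc(N[C@H]3CC[C@H](N)CC3)nc21`: 380 nM
compound 3 `CCCCCCn1cnc2c(Nc3ccc(O)cc3)nc(N[C@H]3CC[C@H](N)CC3)nc21`: 190 nM

In a functional assay on EOL1 cells (Homo sapiens) for inhibition, read by fluorescence, with a stated time of 72 h (on this read-out lower numbers stand for stronger inhibition of growth and higher numbers for weaker inhibition of growth), compound 3 gives 190 nM, which lies within the scatter of both compound 1 and compound 2. Compound 4 `N[C@H]1CC[C@H](Nc2nc(Nc3ccc(O)cc3)c3ncn(C4CCCCC4)c3n2)CC1` carries cyclohexyl in place of hexyl on an aromatic nitrogen. Going by the values given here, the only measured step, a 2.0-fold lower number from compound 2 to compound 3 (0.30 log units; within the scatter), lies within the scatter and concerns a different place, so it does not test this change. Compound 1 already carries cyclohexyl and gives 140 nM, but it also differs from compound 4 in another group. No step beyond the scatter is therefore expected. The estimated step is a 1.3-fold lower number from compound 3 to compound 4 (0.10 log units; within the scatter). Compound 4 is expected at 150 nM, within an estimated range of 55 nM to 400 nM.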

Compound 4, concentration for 50% growth inhibition: 220 nM
Beside the measured number, compound 4's estimate is 1.5-fold (0.17 log units) below it, and the stated range covers the measured number.
By their numbers in this assay, from the lowest: compounds 1, 3, 4 and 2 (each within the scatter of the next, the first and the last beyond it).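

In this assay hexyl gives way to cyclohexyl on the aromatic nitrogen with a 1.2-fold higher number from compound 3 to compound 4 (0.06 log units; within the scatter) and so this position takes the ring as well as the open chain without a step beyond the scatter. With cyclohexyl held in place, hydroxy in place of chloro on an aromatic carbon gives a 1.6-fold higher number from compound 1 to compound 4 (0.20 log units; within the scatter) and this too stays within the scatter. Nothing available gives a reason for these results. The compounds shown leave open whether a shorter chain such as ethyl on that nitrogen would read differently, and whether an amine or a carboxylic acid in place of hydroxy would produce a step beyond the scatter.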